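Methyl in Place of Chloro on Compound 3

The source may report more compounds than this note shows. Statements on the series, on what has been measured and on what is new or still open speak of the compounds shown alone.

In a functional assay on NCI-H460 cells (Homo sapiens) for antiproliferative activity, read by sulforhodamine B assay, with a stated time of 48 h (a higher number here means a weaker inhibitor, a lower number a stronger inhibitor), compound 1 `O=C(CCCCCCN1C(=O)/C(=N\O)c2cc(Br)ccc21)NO` gives 970 nM and compound 2 `CO/N=C1/C(=O)N(CCCCCCC(=O)NO)c2ccc(F)cc21` gives 970 nM, while compound 3 `CO/N=C1/C(=O)N(CCCCCCC(=O)NO)c2ccc(Cl)cc21` gives 760 nM and so stands within the scatter of both others. Compound 4 `CO/N=C1/C(=O)N(CCCCCCC(=O)NO)c2ccc(C)cc21` differs from compound 3 by methyl in place of chloro on an aromatic carbon and keeps everything else. Within the data shown here, one measured step bears on this carbon: chloro in place of fluoro gave a 1.3-fold lower number from compound 2 to compound 3 (0.11 log units; within the scatter) as its result. Among the measured compounds shown here, a single small step is thin evidence, and no measured compound carries methyl there. The estimated step is a 1.1-fold higher number from compound 3 to compound 4 (0.05 log units; within the scatter) and so no shift beyond the scatter is expected in this assay here. For compound 4 the expected value is 850 nM with an estimated range from 400 nM to 1800 nM as its likely span.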

Compound 4, half-maximal inhibitory concentration: 1190 nM
Beside the measured number, compound 4's estimate is 1.4-fold (0.15 log units) below it, and the stated range covers the measured number.
By their numbers in this assay, from the lowest: compounds 3, 1, 2 and 4 (each within the scatter of the next).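

In this assay, methyl on this aromatic carbon was read against both halogens: against chloro (a 1.6-fold higher number from compound 3 to compound 4 (0.19 log units; within the scatter)) and against fluoro (a 1.2-fold higher number from compound 2 to compound 4 (0.09 log units; within the scatter)). Fluoro, chloro and methyl have now all been placed on this carbon, and every step among them stays within the scatter, so the methyl for halogen exchange shows no clear effect here. No available evidence bears on these small differences.

The compounds shown leave open whether an amine or a carboxylic acid on this carbon would go beyond the scatter. They also leave open how methyl would read with the oxime hydroxyl of compound 1 in place of the methoxy group.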